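Swapping chloro for methyl on the benzoyl ring

The source may report more compounds than this note shows. Statements on the series, on what has been measured and on what is new or still open speak of the compounds shown alone.

Measured compounds:
- compound 1, `COc1cc(-c2nnc3n2NC(c2ccco2)C(C(=O)c2ccc(Cl)cc2)S3)cc(OC)c1OC`: 78600 nM
- compound 2, `COc1cc(-c2nnc3n2NC(c2cccs2)C(C(=O)c2ccc(F)cc2)S3)cc(OC)c1OC`: 54200 nM
- compound 3, `COc1ccc(C(=O)C2Sc3nnc(-c4cc(OC)c(OC)c(OC)c4)n3NC2c2cccs2)cc1`: 68000 nM

All three numbers come from a functional assay on HepG2 cells (Homo sapiens) for cytotoxicity, read by MTT assay, with a stated time of 48 h; a higher number here means a weaker inhibitor, a lower number a stronger inhibitor. The three values sit close together: compound 1 is not separated from compound 3 or from compound 2 by more than the usual scatter of this assay, so nothing distinguishes them on the evidence shown.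

Compound 4, `COc1cc(-c2nnc3n2NC(c2ccco2)C(C(=O)c2ccc(C)cc2)S3)cc(OC)c1OC`, is compound 1 with one change: methyl in place of chloro on an aromatic carbon. The new compound has not been tested yet.

Going by the values given here, no measured pair carries the same change. Among the compounds with values here, the only single-point step that has been measured, a 1.3-fold higher number from compound 2 to compound 3 (0.10 log units; within the scatter), exchanges one group on the same aromatic ring for another and leaves the number within the scatter. That step concerns different groups, so it bears on the present question only loosely, yet it is the closest guide available, and it suggests that a swap of one small group for another at this place does not move the read-out far.

For that reason compound 4 is expected to stay near compound 1, with an estimated step of a 1.0-fold lower number from compound 1 to compound 4 (0.02 log units; within the scatter). The estimate for compound 4 in this assay is 75000 nM, within a range from 35000 nM to 160000 nM.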

Compound 4, half-maximal inhibitory concentration: 17400 nM
Estimate against measurement, compound 4: 4.3-fold (0.63 log units) above; measured number below the stated range.
By their numbers in this assay, from the lowest: compound 4; then compounds 2, 3 and 1 (each within the scatter of the next).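

Within this assay, the change from 4-chlorophenyl to 4-methylphenyl gives a 4.5-fold lower number from compound 1 to compound 4 (0.65 log units; beyond the scatter), so this place on the aromatic ring can move the number beyond the scatter. The earlier step, a 1.3-fold higher number from compound 2 to compound 3 (0.10 log units; within the scatter), exchanged methoxy for fluoro on an aromatic carbon and stayed within the scatter, so it gave no sign that a single swap here could matter; the result therefore shows that the identity of the group counts, not just the presence of a small group. The swap is also a close one on paper, with one heavy atom leaving, one entering, and no change in the counted hydrogen-bond donors, acceptors or net charge, and nothing available here accounts for the shift.

The compounds shown leave open whether methyl would lower the number in the same way on the other compounds in this set, since the step rests on a single pair. They also leave open whether a longer chain such as ethyl, or a group such as an amine or a carboxylic acid, would lower the number further at this place or raise it again.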